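Changing the aryl group on the aromatic nitrogen

The source may hold more compounds than are shown below. What is called first, only, known or untested is meant among the compounds shown, and "the series" means these compounds.

Three compounds have been tested in a functional assay on PC-12 cells (Rattus norvegicus) for cytotoxicity, read by MTT assay, with stated times of 2 h and 24 h, tested at 10 uM; a higher number here means a stronger effect of the compound at the concentration tested, a lower number a weaker effect:
compound 1 `Cc1ccc(-n2nc(-c3ccc(C(F)(F)F)cc3O)nc2-c2ccccc2O)cc1` gives 102%;
compound 2 `CC(C)c1ccc(-n2nc(-c3ccc(C(F)(F)F)cc3O)nc2-c2ccccc2O)cc1` gives 108%;
compound 3 `Oc1cc(C(F)(F)F)ccc1-c1nc(-c2ccccc2O)n(-c2ccccc2C(F)(F)F)n1` gives 92.2%.

Compound 3 stands at the bottom of these three numbers, though its distance to compound 1 is small, a number 9.8 percentage points lower from compound 1 to compound 3 (within the scatter), while the gap to compound 2 is larger, a number 15.8 percentage points lower from compound 2 to compound 3 (beyond the scatter). The two higher compounds differ from each other only slightly, a number 6 percentage points higher from compound 1 to compound 2 (within the scatter).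

Compound 4 `Oc1cc(C(F)(F)F)ccc1-c1nc(-c2ccccc2O)n(-c2ccc(F)cc2F)n1` has not yet been measured. It differs from compound 3 at the group on the aromatic nitrogen: 2,4-difluorophenyl in place of 2-(trifluoromethyl)phenyl on an aromatic nitrogen. Among the measured compounds shown here, the steps that bear on this place are the two in which that group was exchanged, and both were small or at most modest. Nothing here indicates a large movement from a further exchange at this place, so compound 4 is expected to stay close to compound 3, with an estimated step of a number 2.8 percentage points higher from compound 3 to compound 4 (within the scatter). For compound 4 the estimate in this assay is 95%, with a range from 80% to 110%.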

Compound 4, a percentage reported as activity, at one concentration (the size of the read-out at that concentration, not a potency): 97.9%
The estimate for compound 4 lay 2.9 percentage points below the measured number, within the range that was stated.
By their numbers in this assay, from the lowest: compounds 3, 4, 1 and 2 (each within the scatter of the next, the first and the last beyond it).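

In this assay, the 2,4-difluorophenyl group, which has fewer heavy atoms than the 2-(trifluoromethyl)phenyl it replaces, gives a number 5.7 percentage points higher from compound 3 to compound 4 (within the scatter), so this exchange on the aromatic nitrogen leaves the read-out unresolved from that of the earlier ortho-free comparison only in the sense that no real change can be claimed. Against the two alkyl-bearing aryl groups the result is split: a number 4.1 percentage points lower from compound 1 to compound 4 (within the scatter), whereas a number 10.1 percentage points lower from compound 2 to compound 4 (beyond the scatter), so 4-isopropylphenyl alone stands apart from both fluorinated groups, as it did from compound 3. Nothing measured here accounts for these steps.

Going by these compounds, all four compounds carry a substituted phenyl on this nitrogen, so it remains open whether an aminophenyl, a carboxylic acid on that ring or a plain alkyl chain would stay in this range. The read-out comes from a single concentration and gives no potency for any of them.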